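A few compounds are considered here, and "the series" means these few. Any claim that something is new, unique, unknown or untested is made for them only; others in the source may bear on it.

Three compounds have so far been measured in a functional assay on the whole organism (blood, strain Wistar-Okamoto) with Rattus norvegicus as the target, with a stated time of 5 days; on this read-out higher numbers stand for an effect only at larger amounts of compound and lower numbers for an effect already at smaller amounts:

compound 1 `CC(C)(C)/N=C(\NC#N)Nc1ccncc1`, 2.5 mg/kg
compound 2 `CCC(C)(C)/N=C(\NC#N)Nc1ccncc1`, 2.5 mg/kg
compound 3 `CC(C)C(C)(C)/N=C(\NC#N)Nc1ccncc1`, 20 mg/kg

All three share one core and differ only in the saturated chain carried on the double-bonded nitrogen. Compound 3 stands highest of the three numbers: compound 1 is its nearest neighbour, with an 8.0-fold higher number from compound 1 to compound 3 (0.90 log units; beyond the scatter), and compound 2 lies just as far away, with an 8.0-fold higher number from compound 2 to compound 3 (0.90 log units; beyond the scatter). Between the two lower compounds the data show no change at the digits printed from compound 1 to compound 2 (within the scatter), so nothing separates them.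

Compound 4 `CC(C)(C)CC(C)(C)/N=C(\NC#N)Nc1ccncc1` has not yet been measured in this assay. It differs from compound 3 in one place: neopentyl in place of isopropyl on a saturated chain carbon bound to a double-bonded nitrogen and two saturated chain carbons The two measured steps that bear on this change are the ones that alter the group on the same saturated chain carbon: an 8.0-fold higher number from compound 1 to compound 3 (0.90 log units; beyond the scatter) and an 8.0-fold higher number from compound 2 to compound 3 (0.90 log units; beyond the scatter). Both moved the number upward by a modest amount, and a still larger group now enters at that position. For compound 4 a further upward step is therefore expected, estimated as a 2.0-fold higher number from compound 3 to compound 4 (0.30 log units; within the scatter). Compound 4 is thus expected to give about 40 mg/kg in this assay, estimated to fall between 10 mg/kg and 160 mg/kg.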

Compound 4, minimum effective dose: 50 mg/kg
Compound 4: middle estimate off by 1.3-fold (0.10 log units), on the low side; low and high end bracket the measured number.
By their numbers in this assay, from the lowest: compounds 1 and 2 (each within the scatter of the next); then compound 3; then compound 4.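

Neopentyl in place of isopropyl on this saturated chain carbon shows that in this assay the number does not stop rising once isopropyl is reached, with a 2.5-fold higher number from compound 3 to compound 4 (0.40 log units; beyond the scatter) as a further step. The carbon two bonds along the chain from the double-bonded nitrogen also looks different now: methyl there made no difference between compound 1 and compound 2, yet tert-butyl in place of that methyl gives a 20-fold higher number from compound 2 to compound 4 (1.30 log units; beyond the scatter) and tert-butyl in place of hydrogen gives a 20-fold higher number from compound 1 to compound 4 (1.30 log units; beyond the scatter) in the same read-out. Across these four compounds a larger group therefore goes with a higher number, meaning more compound is needed for an effect, and the one exception is compound 2, whose number cannot be told apart from that of compound 1 despite its added methyl.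

The compounds shown leave open whether total size or the branching of these chains is what tracks the number, and a straight pentyl chain or a cyclohexyl ring at this place would help to separate the two. No measurement at hand speaks to why the number rises.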